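A few compounds are considered here, and "the series" means these few. Any claim that something is new, unique, unknown or untested is made for them only; others in the source may bear on it.

Measured in a functional assay on RXF 393 cells (Homo sapiens) for inhibition, read by sulforhodamine B assay, with a stated time of 48 h; on this read-out lower numbers stand for higher toxicity in this test and higher numbers for lower toxicity in this test:
Compound 1 `Nc1cc(N)c2nc(-c3ccccc3)c(Oc3ccc(Cl)c(Cl)c3)nc2c1`: < 100000 nM, a limit of the assay.
Compound 2 `Nc1cc(N)c2nc(-c3ccccc3)c(NCc3ccc(F)cc3)nc2c1`: 60300 nM.
Compound 3 `COc1ccc(Sc2nc3cc(N)cc(N)c3nc2-c2ccccc2)cc1`: < 100000 nM, a limit of the assay.

Compound 3 stands only at a limit in this assay, as the limit of < 100000 nM in this assay, at which 2 of the 3 values shown sit, records. Compound 4 `Nc1cc(N)c2nc(-c3ccccc3)c(Sc3ccc(Cl)c(Cl)c3)nc2c1` differs from it by 3,4-dichlorophenyl in place of 4-methoxyphenyl on a sulfur. The steps that touch this pair are a step that the two limits leave unreadable from compound 1 to compound 3 and a step that the limit leaves unreadable from compound 2 to compound 3, and likewise a step that the limit leaves unreadable from compound 1 to compound 2; none of them has a readable size. Compound 1 carries the same dichloro-substituted ring and sits at the limit, so compound 4 is expected to stay near the limit, with a step estimated as a number no lower from compound 3 to compound 4 (the limit leaves the size open). Compound 4 is accordingly estimated at 100000 nM, within 40000 nM to 250000 nM.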

Compound 4, concentration lethal to 50% of the cells: 60300 nM
Compound 4: the middle estimate sits 1.7-fold (0.22 log units) above what was measured; low and high end bracket the measured number.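

In this assay, (3,4-dichlorophenyl)sulfanyl on this aromatic carbon gives a measured number where the earlier sulfur compound, compound 3, stands only at a limit. Set against (4-fluorobenzyl)amino, the exchange shows no change at the digits printed from compound 2 to compound 4 (within the scatter), so these two different groups read alike here. The steps involving compound 1 and compound 3 cannot be read: the limit of < 100000 nM in this assay, at which 2 of the 4 values shown sit.

Still open, going by these compounds, is how an amine or a carboxylic acid on the ring held by the sulfur would read. A longer chain between that sulfur and its ring also remains untested among the compounds shown.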